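This account rests on a few compounds, and the source may have more. Where it says the series, first, only, none or still open, it means among the compounds named here.

Compound 1 `Cc1ccc(NC(=O)c2ccc(CN3CCCN(C)CC3)cc2)cc1-n1cc(-c2cnc3ccnn3c2)cn1`, in a functional assay on U-937 cells (Homo sapiens) for antiproliferative activity, read by CCK-8 assay, with a stated time of 24 h; on this read-out lower numbers stand for stronger inhibition and higher numbers for weaker inhibition: 6830 nM.
Compound 2 `Cc1ccc(NC(=O)c2ccc(F)cc2)cc1-n1cc(-c2cnc3cccnn23)cn1`, in this assay: > 20000 nM, which is a limit of the assay.
Compound 3 `Cc1ccc(NC(=O)c2cccc(Cl)c2)cc1-n1cc(-c2cnc3cccnn23)cn1`, in this assay: > 20000 nM, which is also a limit of the assay.

For the measured compounds named here, compound 1 thus gives the only number in this assay; the other two values are limits, and the step that the two limits leave unreadable from compound 2 to compound 3 cannot be read from them. Compounds 2 and 3 moreover carry a core that differs from the core of compound 1, so neither bears directly on the change studied here.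

Compound 4 `Cc1ccc(NC(=O)c2ccc(C(F)(F)F)cc2)cc1-n1cc(-c2cnc3ccnn3c2)cn1` differs from compound 1 by trifluoromethyl in place of (4-methyl-1,4-diazepan-1-yl)methyl on an aromatic carbon. Going by the values given here, no measured step covers this change. What the data do show is that two compounds carrying small substituents on the amide-bearing ring both sit at the limit of > 20000 nM in this assay, at which 2 of the 3 values shown sit, whereas compound 1, with its larger basic group, gives a number. On that basis compound 4 is expected to be weaker than compound 1 in this assay, with the step of a 2.2-fold higher number from compound 1 to compound 4 (0.34 log units; beyond the scatter) expected, and a fair chance that only a limit is reported. The estimate for compound 4 is 15000 nM, within 5000 nM to 40000 nM.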

Compound 4, half-maximal inhibitory concentration: 13100 nM
Beside the measured number, compound 4's estimate is 1.1-fold (0.06 log units) above it; low and high end bracket the measured number.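

The exchange of (4-methyl-1,4-diazepan-1-yl)methyl for trifluoromethyl on this aromatic carbon gives a 1.9-fold higher number from compound 1 to compound 4 (0.28 log units; within the scatter) in this assay and so leaves the two compounds level. For the compounds shown here, compound 4 thus shows what the earlier compounds could not: on the shared core, a number is still obtained at this position without the seven-membered ring. Compound 2 and compound 3 remain limits on a different core and add nothing to this comparison: the limit of > 20000 nM in this assay, at which 2 of the 4 values shown sit.

Going by these compounds, it remains open whether another group at this position, such as a carboxylic acid, a morpholine or a plain dimethylaminomethyl chain, would move the number beyond the scatter. On these data alone, it is also open whether a hydrogen or a methyl there would still give a number on the core of compound 1.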